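From butyl to benzyl on a shared core

The source may report more compounds than this note shows. Statements on the series, on what has been measured and on what is new or still open speak of the compounds shown alone.

In an ADME assay on L6 cells (Rattus norvegicus) for cytotoxicity (on this read-out lower numbers stand for stronger inhibition and higher numbers for weaker inhibition), compound 1 `O=c1c2cc([N+](=O)[O-])ccc2[nH]n1Cc1ccccc1` gives 234000 nM, compound 2 `CCCn1c2ccc([N+](=O)[O-])cc2c(=O)n1Cc1ccccc1` gives 77400 nM and compound 3 `CCCCn1c2ccc([N+](=O)[O-])cc2c(=O)n1Cc1ccccc1` gives 46700 nM. Compound 3 thus stands level with compound 2 within the scatter, and clearly lower than compound 1. Compound 4 `O=c1c2cc([N+](=O)[O-])ccc2n(Cc2ccccc2)n1Cc1ccccc1` differs from compound 3 by phenyl in place of propyl on a saturated chain carbon bound to an aromatic nitrogen, which is phenyl in place of propyl on a saturated chain carbon bound to an aromatic nitrogen. Replacing the hydrogen on the aromatic nitrogen gave modest steps, a 3.0-fold lower number from compound 1 to compound 2 (0.48 log units; beyond the scatter) and a 5.0-fold lower number from compound 1 to compound 3 (0.70 log units; beyond the scatter). The change on the chain itself, a 1.7-fold lower number from compound 2 to compound 3 (0.22 log units; within the scatter), stayed within the scatter. For the measured compounds named here, no measured compound carries benzyl in that place, so no step beyond the scatter is expected in this assay. The expected change is a 1.3-fold lower number from compound 3 to compound 4 (0.13 log units; within the scatter). For compound 4 the estimated value is 35000 nM, with an expected range from 12000 nM to 90000 nM.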

Compound 4, half-maximal inhibitory concentration: 37300 nM
Compound 4: the middle estimate sits 1.1-fold (0.03 log units) below what was measured; the range from low to high includes it.
By their numbers in this assay, from the lowest: compounds 4, 3 and 2 (each within the scatter of the next, the first and the last beyond it); then compound 1.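

In this assay, benzyl in place of hydrogen on the aromatic nitrogen also lowers the number (a 6.3-fold lower number from compound 1 to compound 4 (0.80 log units; beyond the scatter)), so a group carrying an aromatic ring serves at this position as the propyl and butyl chains did. Exchanging the chain for the ring gives a 1.3-fold lower number from compound 3 to compound 4 (0.10 log units; within the scatter) from butyl to benzyl, while the same comparison with the shorter chain gives a 2.1-fold lower number from compound 2 to compound 4 (0.32 log units; beyond the scatter). Nothing available gives a reason for these steps. Still open, on these data alone, is how a longer chain, an amine or a carboxylic acid would read at this position, and whether a substituted benzyl would shift the number.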